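Swapping Benzoyloxymethyl for Carbamoyl on the Shared Core

The compounds below may be only part of what the source reports. "The series", "measured", "known", "first", "only" and "open" are said of these compounds alone.

Three compounds on one core were read in a physicochemical assay for solubility, read by HPLC, with a stated time of 24 h; on this read-out higher numbers stand for higher solubility and lower numbers for lower solubility. Compound 1 `O=C1O[C@@H](CN2CCC(c3ccc(F)cc3)CC2)CN1c1ccc(-n2cc(-c3ccccn3)cn2)c(F)c1` reaches only the limit <= 19400 nM there. Compound 2 `O=C(OC[C@H]1CN(c2ccc(-n3cc(-c4ccccn4)cn3)c(F)c2)C(=O)O1)c1ccccc1` likewise stops at the limit <= 65400 nM in this assay. Compound 2 thus stands at a bound rather than a number, as the limit of <= 65400 nM in this assay, at which 1 of the 3 values shown sits, records, and compound 1 sits at another bound, (the limit of <= 19400 nM in this assay, at which 1 of the 3 values shown sits). Among the measured compounds shown here, compound 3 `O=C1O[C@@H](CNC(=O)C(F)(F)F)CN1c1ccc(-n2cc(-c3ccccn3)cn2)c(F)c1` is the one compound with a measured figure, giving 114000 nM in this assay.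

For the measured compounds named here, the single measured step, an at least 1.7-fold higher number from compound 2 to compound 3 (0.24 log units; that floor lies within the scatter), exchanges benzoyloxy for ((trifluoromethyl)carbonyl)amino on a saturated chain carbon; because compound 2 is a limit, that step is only a floor.

Compound 4 `NC(=O)[C@H]1CN(c2ccc(-n3cc(-c4ccccn4)cn3)c(F)c2)C(=O)O1` differs from compound 2 by carbamoyl in place of (benzoyloxy)methyl on a saturated ring carbon. The step from compound 2 to compound 3 is the only one that bears on it, and both changes remove the benzoyloxy fragment in favour of a far smaller group. A move toward higher solubility is therefore expected, its size uncertain, since the measured step gives only a floor. Compound 4 is expected to give about 150000 nM in this assay, estimated between 50000 nM and 400000 nM. That estimate means an expected step of an at least 2.2-fold higher number from compound 2 to compound 4 (0.36 log units; beyond the scatter).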

Compound 4, solubility: 27200 nM
Beside the measured number, compound 4's estimate is 5.5-fold (0.74 log units) above it; measured number outside the range, below it.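

In this assay, the saturated ring carbon next to the ring oxygen does not treat all small replacements for the benzoyloxy-bearing group alike: carbamoyl in place of (((trifluoromethyl)carbonyl)amino)methyl gives a 4.2-fold lower number from compound 3 to compound 4 (0.62 log units; beyond the scatter). Among the compounds shown here, compound 4 therefore adds a comparison at this ring carbon that the earlier compounds could not give, with a number read on both sides of the change, and it shows that the two groups are not interchangeable on this read-out. Compound 2 is held only by a limit, so the step from it to compound 4 cannot be read, and no direction can be stated for leaving (benzoyloxy)methyl for carbamoyl: the limit of <= 65400 nM in this assay, at which 1 of the 4 values shown sits.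

The compounds shown leave open whether the lower number goes with the loss of the trifluoromethyl group or with carbamoyl sitting directly on the ring carbon, as compound 3 and compound 4 differ in both. Also open, as far as these compounds go, is how a longer chain ending in carbamoyl, a carboxylic acid or an amine on the same ring carbon would read in this assay.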